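The source may hold more compounds than are shown below. What is called first, only, known or untested is meant among the compounds shown, and "the series" means these compounds.

In a functional assay on Ehrlich cells (Mus musculus) for cytotoxicity, read by trypan blue exclusion, with a stated time of 2 h, tested at 100 ug/mL (on this read-out lower numbers stand for a stronger effect and higher numbers for a weaker effect at the one concentration tested), compound 1 `Cc1c(C(=O)N=[N+]=[N-])[n+]([O-])c2cc(Cl)ccc2[n+]1[O-]` gives 81.8%, the highest of the two numbers recorded. Its nearest neighbour is compound 2 `COc1ccc2c(c1)[n+]([O-])c(C(=O)N=[N+]=[N-])c(C)[n+]2[O-]`, which in this assay gives 56%. Among the measured compounds shown here, the only measured step, a number 25.8 percentage points lower from compound 1 to compound 2 (beyond the scatter), arises from a methoxy in place of chloro on an aromatic carbon. Compound 3 `Cc1c(NC(=O)OC(C)C)[n+]([O-])c2cc(Cl)ccc2[n+]1[O-]` differs from compound 1 at another place: a group of 7 heavy atoms (4 carbon, 1 nitrogen, 2 oxygen; no ring) in place of a group of 5 heavy atoms (1 carbon, 3 nitrogen, 1 oxygen; no ring), on an aromatic carbon. For the measured compounds named here, no measured step touches this position, so the step from compound 1 to compound 2 offers no guide to the size or direction of the change, and the chloro-bearing core is shared by compound 1 and compound 3. Going by the values given here, with no precedent, the number for compound 3 is expected to stay near that of compound 1, and the step of a number 5.8 percentage points lower from compound 1 to compound 3 (within the scatter) is expected to fall within the scatter, with a wide range. Compound 3 is therefore estimated to give 76%, between 45% and 100%.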

Compound 3, a percentage reported as activity, at one concentration (the size of the read-out at that concentration, not a potency): 92%
Estimate against measurement, compound 3: 16 percentage points below; the measured number falls inside the stated range.
By their numbers in this assay, from the lowest: compound 2; then compound 1; then compound 3.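

The earlier compounds shown here showed only that this assay responds to methoxy in place of chloro on the aromatic ring, and compound 3 now shows that the position next to the ring nitrogen also matters, with a number 10.2 percentage points higher from compound 1 to compound 3 (beyond the scatter) on replacing the group of compound 1 by (isopropoxycarbonyl)amino. This step runs opposite in direction to a number 25.8 percentage points lower from compound 1 to compound 2 (beyond the scatter) and is the smaller of the two, so this change leaves a weaker effect at the one concentration tested. Nothing available accounts for this shift.

The compounds shown leave open what an amine, a carboxylic acid or a longer chain in place of the isopropyl part would give at this position. They also leave open whether (isopropoxycarbonyl)amino would move the number the same way on the core of compound 2.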